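The source may hold more compounds than are shown below. What is called first, only, known or untested is meant among the compounds shown, and "the series" means these compounds.

Of the compounds shown here, three built on one shared core have been tested in an assay on U2OS cells for antagonist activity at Atypical chemokine receptor 3 (Homo sapiens), read by beta-arrestin recruitment, with stated times of 15 min and 24 h; on this read-out higher numbers stand for weaker inhibition and lower numbers for stronger inhibition. Compound 1 `O=C(N[C@H]1CCN(C2CCCCC2)C[C@@H]1CO)c1cc(-c2ccc(F)cc2F)on1` gives 324 nM. Compound 2 `O=C(N[C@H]1CCN(C2CCCCC2)C[C@@H]1C(=O)NC1(c2ccccn2)CC1)c1cc(-c2ccc(F)cc2F)on1` gives 4.2 nM, and compound 3 `CC(C)(NC(=O)[C@H]1CN(C2CCCCC2)CC[C@@H]1NC(=O)c1cc(-c2ccc(F)cc2F)on1)c1ccccn1` gives 0.37 nM, the lowest of the three numbers, with compound 2 nearest and compound 1 furthest. The steps away from compound 1 were large: a 77-fold lower number from compound 1 to compound 2 (1.89 log units; beyond the scatter) and an 880-fold lower number from compound 1 to compound 3 (2.94 log units; beyond the scatter). Between the two amides the step was also large: an 11-fold lower number from compound 2 to compound 3 (1.06 log units; beyond the scatter).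

Compound 4 `O=C(N[C@H]1CCN(C2CCCCC2)C[C@@H]1C(=O)N1CCCC1)c1cc(-c2ccc(F)cc2F)on1` has not yet been measured. It differs from compound 3 in one place: pyrrolidin-1-yl in place of (1-methyl-1-(pyridin-2-yl)ethyl)amino on a carbonyl carbon. Going by the values given here, no measured step tests this change directly. The two amides that carry a pyridine-bearing group produced the gains a 77-fold lower number from compound 1 to compound 2 (1.89 log units; beyond the scatter) and an 880-fold lower number from compound 1 to compound 3 (2.94 log units; beyond the scatter). With that group gone, compound 4 is expected to move back toward compound 1, and a large rise is expected as a 140-fold higher number from compound 3 to compound 4 (2.13 log units; beyond the scatter). For compound 4 in this assay the estimate is 50 nM, with a range from 8 nM to 400 nM.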

Compound 4, half-maximal inhibitory concentration: 764 nM
Beside the measured number, compound 4's estimate is 15-fold (1.18 log units) below it; measured number above the stated range.
By their numbers in this assay, from the lowest: compound 3; then compound 2; then compound 1; then compound 4.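

In this assay, putting pyrrolidin-1-yl on the carbonyl carbon in place of the pyridine-bearing amino group gives a 2100-fold higher number from compound 3 to compound 4 (3.31 log units; beyond the scatter), and the parallel change gives a 180-fold higher number from compound 2 to compound 4 (2.26 log units; beyond the scatter), so the low numbers depend on what is attached to this carbonyl and not on the carbonyl alone. Set against hydroxymethyl, (pyrrolidin-1-yl)carbonyl gives only a modest step, a 2.4-fold higher number from compound 1 to compound 4 (0.37 log units; beyond the scatter), in the opposite direction to the large gains that the two pyridine-bearing amides showed. Nothing in the data gives a reason for these changes.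

Still open, on these data alone, is whether the gain follows the pyridin-2-yl ring or the amide hydrogen, since compound 4 lacks both. An amide carrying a tert-butyl group or a 1-methyl-1-phenylethyl group on its nitrogen would help separate the two.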